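Phenyl to 3,5-dihydroxyphenyl in the series

The compounds below may be only part of what the source reports. "The series", "measured", "known", "first", "only" and "open" are said of these compounds alone.

Measured so far in a functional assay on MCF7 cells (Homo sapiens) for cytotoxicity; a lower number here means a stronger inhibitor, a higher number a weaker inhibitor
- compound 1 `C=C/C=C\[C@H](C)[C@H](OC(N)=O)[C@@H](C)[C@H](O)[C@@H](C)C/C(C)=C\[C@H](C)[C@@H](O)[C@@H](C)/C=C\CCc1cccc(O)c1C` gives 1000 nM
- compound 2 `C=C/C=C\[C@H](C)[C@H](OC(N)=O)[C@@H](C)[C@H](O)[C@@H](C)C/C(C)=C\[C@H](C)[C@@H](O)[C@@H](C)/C=C\CCc1ccccc1` gives 560 nM

Within the data shown here, on these two numbers compound 2 cannot be separated from compound 1, the only other measured compound in this assay. Compound 3 `C=C/C=C\[C@H](C)[C@H](OC(N)=O)[C@@H](C)[C@H](O)[C@@H](C)C/C(C)=C\[C@H](C)[C@@H](O)[C@@H](C)/C=C\CCc1cc(O)cc(O)c1` is next, with 3,5-dihydroxyphenyl in place of phenyl on a saturated chain carbon, two bonds along the chain from a double-bonded chain carbon. Among the measured compounds shown here, one measured step bears on this, an exchange at the same place that stayed within the scatter (a 1.8-fold lower number from compound 1 to compound 2 (0.25 log units; within the scatter)). The expected step is therefore none beyond the scatter (a 1.4-fold higher number from compound 2 to compound 3 (0.15 log units; within the scatter)). Compound 3 is estimated at 800 nM, with an expected range of 250 nM to 2500 nM.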

Compound 3, half-maximal inhibitory concentration: > 1000 nM
Compound 3 was reported as a limit (the forecaster's own chance of this, stated with the estimate: 10%); middle value at least 1.2-fold (0.09 log units) from the limit.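

In this assay compound 3 gives > 1000 nM, which is a limit of the assay and not a number. With 3,5-dihydroxyphenyl in place of phenyl the result is an at least 1.7-fold higher number from compound 2 to compound 3 (0.25 log units; that floor lies within the scatter), so this change brings no lower number at this position, though the floor does not separate the two compounds. With 3,5-dihydroxyphenyl in place of 3-hydroxy-2-methylphenyl the result is a number no lower from compound 1 to compound 3 (the limit leaves the size open).

From the compounds shown here alone, the true size of the step to compound 3 stays open. Also open, going by these compounds, is how an amine or a carboxylic acid on the phenyl, or a longer chain, would read here.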